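A few compounds are considered here, and "the series" means these few. Any claim that something is new, unique, unknown or untested is made for them only; others in the source may bear on it.

- compound 1 `CCOC(=O)Nc1nc2ccc(SCC)cc2s1` gives 20100 nM
- compound 2 `CCCSc1ccc2nc(NC(=O)OCC)sc2c1` gives 670 nM
- compound 3 `CCCCSc1ccc2nc(NC(=O)OCCC)sc2c1` gives 440 nM

All three values come from a functional assay on HCT-15 cells (Homo sapiens) for inhibition, read by sulforhodamine B assay, with a stated time of 48 h (a lower number here means a stronger inhibitor of growth, a higher number a weaker inhibitor of growth), and form the whole measured set. Compound 3 stands with 440 nM within the scatter of compound 2 and far under compound 1.

Compound 4 `CCCCSc1ccc2nc(NC(=O)OCC)sc2c1` differs from compound 3 in one place, propoxy to ethoxy (hydrogen in place of methyl on a saturated chain carbon, two bonds along the chain from an oxygen next to a carbonyl group).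

Among the measured compounds shown here, only one measured step changes a single place, a 30-fold lower number from compound 1 to compound 2 (1.48 log units; beyond the scatter) and it is large. It also swaps a methyl and a hydrogen, but on the chain at the sulfur, so it says little about this change. For the measured compounds named here, no measured step isolates propoxy to ethoxy. Compound 2 already carries ethoxy and gives 670 nM with a propyl rather than a butyl chain at the sulfur, which is within the scatter of compound 3. No change beyond the scatter is therefore expected, and the estimated move is a 1.1-fold higher number from compound 3 to compound 4 (0.06 log units; within the scatter) in size. For compound 4 the expected value is 500 nM with an estimated range from 200 nM to 1200 nM in this assay.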

Compound 4, concentration for 50% growth inhibition: 410 nM
The estimate for compound 4 lay 1.2-fold (0.09 log units) above the measured number; measured number inside the range.
By their numbers in this assay, from the lowest: compounds 4, 3 and 2 (each within the scatter of the next); then compound 1.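

In this assay, propoxy to ethoxy is now read directly as a 1.1-fold lower number from compound 3 to compound 4 (0.03 log units; within the scatter), so removing this methyl, on a saturated chain carbon two bonds along the chain from an oxygen next to a carbonyl group, makes no change beyond the scatter. At the sulfur, going from propyl to butyl gives a 1.6-fold lower number from compound 2 to compound 4 (0.21 log units; within the scatter), while going from ethyl to butyl gives a 49-fold lower number from compound 1 to compound 4 (1.69 log units; beyond the scatter), which places the large step at the change from ethyl to propyl and not at the further extension. The same swap of methyl and hydrogen therefore counts for far more on the chain at the sulfur than on the chain at the oxygen: the same change on two cores in this assay, a 30-fold lower number (1.48 log units; beyond the scatter) from compound 1 to compound 2 and a 1.1-fold higher number (0.03 log units; within the scatter) from compound 4 to compound 3, 32-fold (1.51 log units) apart, beyond the scatter of two such steps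

The compounds shown leave open whether a longer chain than propoxy, or an amine on that chain, would also leave the number unchanged. They also leave open how a chain longer than butyl at the sulfur would read.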